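A few compounds are considered here, and "the series" means these few. Any claim that something is new, unique, unknown or untested is made for them only; others in the source may bear on it.

In a functional assay on OVCAR-4 cells (Homo sapiens) for inhibition, read by sulforhodamine B assay, with a stated time of 48 h (on this read-out higher numbers stand for weaker inhibition of growth and lower numbers for stronger inhibition of growth), two compounds have been measured. Compound 1, `Nc1cc(N)c2nc(-c3ccccc3)c(Oc3ccc(Cl)c(Cl)c3)nc2c1`, gives 33100 nM. Compound 2, `COc1ccc(CNc2nc3cc(N)cc(N)c3nc2-c2ccccc2)cc1OC`, gives 2690 nM, the lower of the two numbers and thus the stronger inhibition of growth; the gap between the two compounds lies beyond the usual scatter of such measurements. Compound 3, `COc1ccc(CNc2nc3cc(N)cc(N)c3nc2-c2ccccc2)cc1`, has not yet been measured in this assay. It differs from compound 2 in one place: hydrogen in place of methoxy on an aromatic carbon. Among the measured compounds shown here, no step of this kind exists among the measured compounds, so nothing within these data fixes its size. Removal of one methoxy group from a side group of this kind is expected to change the number only a little, most likely by no more than the usual scatter, and if anything towards a slightly weaker inhibition of growth. On that basis the expected step from compound 2 to compound 3 in this assay is a 1.3-fold higher number from compound 2 to compound 3 (0.11 log units; within the scatter). Compound 3 is therefore estimated to give 3500 nM in this assay, with a likely range from 1200 nM to 10000 nM.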

Compound 3, concentration for 50% growth inhibition: 8130 nM
The estimate for compound 3 lay 2.3-fold (0.37 log units) below the measured number; measured number inside the range.
By their numbers in this assay, from the lowest: compound 2; then compound 3; then compound 1.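

In this assay, going from 3,4-dimethoxyphenyl to 4-methoxyphenyl gives a 3.0-fold higher number from compound 2 to compound 3 (0.48 log units; beyond the scatter), so replacing this methoxy group with hydrogen weakens the inhibition of growth. Among the compounds shown here, this is the only comparison so far in which just one place changes, and it shows that this carbon, ortho to the remaining methoxy group, matters to the read-out: losing only two heavy atoms moves the number beyond the usual scatter. Nothing shown here gives independent evidence for the reason behind this step.

The compounds shown carry only methoxy or hydrogen at this position, leaving open how an amine, a hydroxyl group or a longer chain such as ethoxy would read there. Also open, on these data alone, is how much the remaining methoxy group in compound 3 matters, and whether the same change would have a step of similar size on a different core.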